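Methoxy for nitro on compound 1: what to expect

The source may hold more compounds than are shown below. What is called first, only, known or untested is meant among the compounds shown, and "the series" means these compounds.

Compound 1, `COc1cc(N(C)C(=O)c2ccc([N+](=O)[O-])cc2)cc(OC)c1OC`, in a functional assay on ONS-76 cells (Homo sapiens) for cytotoxicity, read by MTT assay, with a stated time of 72 h (on this read-out higher numbers stand for weaker inhibition and lower numbers for stronger inhibition), gives >= 125000 nM.
Compound 2, `COc1cc(NC(=O)c2ccc([N+](=O)[O-])cc2)cc(OC)c1OC`, in this assay gives >= 125000 nM.
Compound 3, `COc1cc(N(C)C(=O)N(C)c2cccc(F)c2)cc(OC)c1OC`, in this assay gives >= 125000 nM.

The value of compound 1 is a limit of this assay, not a measured number. The same holds for compound 2, whose value is also only a limit. The value of compound 3 is likewise a limit and no number. All three therefore sit at the limit of >= 125000 nM in this assay, at which 3 of the 3 values shown sit, and compound 1 stands nowhere in particular among them: no one of the three can be called stronger or weaker than another.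

Among the compounds with values here, the single measured step, hydrogen in place of methyl on an amide-type nitrogen, gives a step that the two limits leave unreadable from compound 1 to compound 2, so it tells nothing about size or direction.

Compound 4, `COc1ccc(C(=O)N(C)c2cc(OC)c(OC)c(OC)c2)cc1`, differs from compound 1 by methoxy in place of nitro on an aromatic carbon. Within the data shown here, no measured step touches this kind of change, so nothing here shows how it should move the value. Since every compound shown stays at the limit, compound 4 is expected to behave the same way, with an estimate of 125000 nM, ranging from 40000 nM to 400000 nM. This means an expected step of a number no higher from compound 1 to compound 4 (the limit leaves the size open), essentially none.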

Compound 4, half-maximal inhibitory concentration: >= 125000 nM
Compound 4: no number, only a limit (the forecaster's own chance of this, stated with the estimate: 80%); the middle value lies on the limit itself.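

In this assay compound 4 gives >= 125000 nM, which is a limit and not a number. Compound 1 also has only a limit, so no step can be read between compound 1 and compound 4, and all the compounds stand together: the limit of >= 125000 nM in this assay, at which 4 of the 4 values shown sit.

The compounds shown leave open what methoxy in place of nitro does to potency, and which change to the shared core would give a measurable value.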